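A Carboxy Swap on the Least Toxic Compound

The source may report more compounds than this note shows. Statements on the series, on what has been measured and on what is new or still open speak of the compounds shown alone.

Measured so far:
- Compound 1 `CNCc1ccc2c(c1)nc(Cn1c(=O)n(C(C)C)c3ccccc31)n2CCC(C)C`: 1480 nM
- Compound 2 `C=C(C)n1c(=O)n(Cc2nc3cc(/C(N)=N\O)ccc3n2CCC(C)C)c2ccccc21`: 3470 nM
- Compound 3 `CC(C)CCn1c(Cn2c(=O)n(C(C)C)c3ccccc32)nc2ccc(CO)cc21`: 81600 nM

These numbers come from an ADME assay on HEp-2 cells (Homo sapiens) for cytotoxicity (on this read-out higher numbers stand for lower toxicity in this test and lower numbers for higher toxicity in this test), which shows how much of a compound is needed to harm the cells. Compound 3 stands highest at 81600 nM, clearly beyond the usual scatter from both other compounds. Compound 4 `CC(C)CCn1c(Cn2c(=O)n(C(C)C)c3ccccc32)nc2ccc(C(=O)O)cc21` keeps everything in compound 3 except one group, with carboxy in place of hydroxymethyl on an aromatic carbon. For the measured compounds named here, no pair of measured compounds differs in only one place, so the data show no direct precedent for this swap, and any forecast is uncertain. The starting point is compound 3 at 81600 nM, and the change is confined to that single group. A small upward move or none is therefore expected, and the expected size, a 1.2-fold higher number from compound 3 to compound 4 (0.09 log units; within the scatter), stays within the scatter. For compound 4 the estimated value is 100000 nM, with an expected range from 30000 nM to 300000 nM.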

Compound 4, half-maximal cytotoxic concentration: 125000 nM
The estimate for compound 4 lay 1.3-fold (0.10 log units) below the measured number, within the range that was stated.
By their numbers in this assay, from the lowest: compound 1; then compound 2; then compounds 3 and 4 (each within the scatter of the next).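

In this assay, carboxy in place of hydroxymethyl on this aromatic carbon gives a 1.5-fold higher number from compound 3 to compound 4 (0.19 log units; within the scatter), so the two compounds cannot be told apart by this test. For the compounds shown here, this is the first comparison in the set in which only one group differs, and it shows that this carbon can carry carboxy, with its extra oxygen, without a measurable shift in harm to the cells. No measurement shown here offers an explanation for this result.

As far as these compounds go, what stays open is whether other groups on the same carbon, such as a methyl ester or a primary amide, would also leave the number this high. Going by these compounds alone, it is also open whether the same swap would behave this way in a compound that differs elsewhere, as this single pair is the only reading of it.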